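Furan-3-yl for Thiophen-3-yl on an Otherwise Inactive Core

This account rests on a few compounds, and the source may have more. Where it says the series, first, only, none or still open, it means among the compounds named here.

Compound 1 `CN(C)c1ncnc2c1c(-c1ccsc1)cn2[C@@H]1O[C@H](CO)[C@@H](O)[C@H]1O` was tested in a functional assay on HCT-116 cells (Homo sapiens), read by MTT assay, with a stated time of 72 h; a higher number here means a weaker inhibitor, a lower number a stronger inhibitor. In that setting compound 1 gives only a limit, > 20000 nM. Compound 2 `CN(C)c1ncnc2c1c(-c1ccoc1)cn2[C@@H]1O[C@H](CO)[C@@H](O)[C@H]1O` differs from compound 1 by furan-3-yl in place of thiophen-3-yl on an aromatic carbon. In this assay compound 2 also gives only a limit, > 20000 nM. The two cores of the series differ in the way described by hydrogen in place of methyl on a nitrogen on an aromatic ring, which turns compound 1 into compound 3 `CNc1ncnc2c1c(-c1ccsc1)cn2[C@@H]1O[C@H](CO)[C@@H](O)[C@H]1O`. In this assay compound 3 likewise gives only a limit, > 20000 nM.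

Neither step can be sized: a step that the two limits leave unreadable from compound 1 to compound 2 and a step that the two limits leave unreadable from compound 1 to compound 3 remain unreadable because both ends of each sit at the limit of > 20000 nM in this assay, at which 3 of the 3 values shown sit.

Compound 4 `CNc1ncnc2c1c(-c1ccoc1)cn2[C@@H]1O[C@H](CO)[C@@H](O)[C@H]1O` has not yet been measured in this assay. For the measured compounds named here, it differs from compound 3 by furan-3-yl in place of thiophen-3-yl on an aromatic carbon, and this is the same change as the one from compound 1 to compound 2, made at the same place. Because compound 3 gives only a limit, > 20000 nM, the step to compound 4 is expected to be a step that the limit leaves unreadable from compound 3 to compound 4, set beside a step that the two limits leave unreadable from compound 1 to compound 2. Compound 4 is therefore estimated at 25000 nM, with the expectation that this assay most likely returns no number but only its limit, and the range from 10000 nM to 80000 nM reflects that.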

Compound 4, half-maximal inhibitory concentration: > 20000 nM
Compound 4 ended at the assay's limit; the forecaster's own chance of this, stated with the estimate: 90%; the middle value does not contradict the limit.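

In this assay compound 4 gives > 20000 nM, which is a limit and not a number. No new step can be read, neither from compound 3 nor from compound 2 to compound 4, because both ends of each step sit at the same limit: the limit of > 20000 nM in this assay, at which 4 of the 4 values shown sit.

The compounds shown leave open how furan-3-yl compares with thiophen-3-yl, and hydrogen with methyl on the nitrogen, in this assay.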